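The compounds below may be only part of what the source reports. "The series", "measured", "known", "first", "only" and "open" are said of these compounds alone.

In a functional assay on NCI-H69 cells (Homo sapiens) for cytotoxicity, read by MTT assay, with a stated time of 3 days (on this read-out lower numbers stand for stronger inhibition and higher numbers for weaker inhibition), compound 1 (`C[C@H]1O[C@@H](n2cc(F)c(NC(=O)Oc3ccc(Cl)cc3)nc2=O)[C@H](O)[C@@H]1O`) gives 90 ug/mL. Among the measured compounds shown here, this is the lower of the two numbers measured so far. The other comes from compound 2 (`CCC(C)COC(=O)Nc1nc(=O)n([C@@H]2O[C@H](C)[C@H]3OC(=O)O[C@H]32)cc1F`), which gives 330 ug/mL, and the gap between them lies beyond the usual scatter.

The next compound, compound 3 (`CCC(C)COC(=O)Nc1nc(=O)n([C@@H]2O[C@H](C)[C@@H](O)[C@H]2O)cc1F`), keeps the core of compound 1 and changes one group: 2-methylbutyl takes the place of 4-chlorophenyl on an oxygen next to a carbonyl group (2-methylbutyl in place of 4-chlorophenyl on an oxygen next to a carbonyl group).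

For the measured compounds named here, no measured pair shows this swap on its own. Going by the values given here, only one measured compound carries 2-methylbutyl, and it also differs from compound 1 elsewhere, so compound 2, at 330 ug/mL, is only a loose guide. On that evidence, a moderate step towards a higher number, meaning weaker inhibition, is expected in this assay, although a step within the scatter cannot be ruled out. The estimated change is a 2.6-fold higher number from compound 1 to compound 3 (0.41 log units; beyond the scatter). For compound 3, the estimated value is 230 ug/mL, with an expected range of 80 ug/mL to 600 ug/mL.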

Compound 3, half-maximal inhibitory concentration: 370 ug/mL
Compound 3: middle estimate off by 1.6-fold (0.21 log units), on the low side; the range from low to high includes it.
By their numbers in this assay, from the lowest: compound 1; then compounds 2 and 3 (each within the scatter of the next).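

In this assay, swapping 4-chlorophenyl for 2-methylbutyl on an oxygen next to a carbonyl group now has a size of its own: a 4.1-fold higher number from compound 1 to compound 3 (0.61 log units; beyond the scatter) and it lies beyond the usual scatter. Compound 2 could not show this, as it also differs from compound 1 elsewhere, whereas compound 1 and compound 3 differ only in this group, so the change in the number can be tied to this position alone. Nothing at hand explains why these two groups give different numbers.

Going by these compounds, a single pair cannot separate what the ring contributes from what the chlorine contributes, so it remains open whether a plain phenyl would sit with compound 1 or with compound 3. It also remains open how the number would respond to a longer chain such as n-octyl, or to a chain ending in an amine, since the compounds shown cover only one aromatic group and one branched chain at this position.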